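Changing the Amide-Nitrogen Aryl Group in a Sulfonamide Series

The compounds below may be only part of what the source reports. "The series", "measured", "known", "first", "only" and "open" are said of these compounds alone.

Measured compounds:
compound 1 `O=C1COc2ccc(-c3cccc(NS(=O)(=O)c4ccc(F)cc4)c3)cc2N1c1ccccc1` gives 17700 nM
compound 2 `COc1cccc(N2C(=O)COc3ccc(-c4cnc(Cl)c(NS(=O)(=O)c5ccc(F)cc5)c4)cc32)c1` gives > 40000 nM
compound 3 `COc1ccc(N2C(=O)COc3ccc(-c4cnc(OC)c(NS(=O)(=O)c5ccc(F)cc5)c4)cc32)cc1` gives 1220 nM

The three measured compounds were tested in a functional assay on HeLa cells (Homo sapiens) for antiproliferative activity, read by MTT assay, with a stated time of 72 h; a lower number here means a stronger inhibitor, a higher number a weaker inhibitor. Compound 1 gives 17700 nM. Compound 3 gives 1220 nM. For compound 2 only a limit is known, > 40000 nM, which is a limit of the assay and not a number; on the numbers shown compound 2 therefore stands at the weak end, at the limit of > 40000 nM in this assay, at which 1 of the 3 values shown sits. The two compounds with a number, compound 1 and compound 3, differ at more than one place, so nothing can be said of a single step between them.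

Compound 4 `O=C1COc2ccc(-c3cnc(Cl)c(NS(=O)(=O)c4ccc(F)cc4)c3)cc2N1c1ccc(F)cc1` has not been measured. It differs from compound 2 in one place: 4-fluorophenyl in place of 3-methoxyphenyl on an amide-type nitrogen in a ring. Among the measured compounds shown here, no measured pair isolates such a change, so the size of this step can only be guessed. Compound 2 sits at the limit, and a change of this kind is expected to move the value only modestly in this assay, with no clear direction beyond the scatter; the step from compound 2 to compound 4 is expected to be an at least 1.3-fold lower number from compound 2 to compound 4 (0.12 log units; that floor lies within the scatter). Compound 4 is therefore estimated at 30000 nM, within a range from 8000 nM to 100000 nM, with a fair chance that the assay again reports only a limit.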

Compound 4, half-maximal inhibitory concentration: > 40000 nM
Compound 4: only a limit was reported (the forecaster's own chance of this, stated with the estimate: 40%); at least 1.3-fold (0.12 log units) between middle value and limit.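

Compound 2 and compound 4 both stand only at a limit of the assay, so no step can be read for 4-fluorophenyl in place of 3-methoxyphenyl on the amide-type nitrogen in a ring: the limit of > 40000 nM in this assay, at which 2 of the 4 values shown sit.

The compounds shown leave open how these two aryl groups compare where the read-out gives a number.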